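Turning one stereocentre in a benzyloxybenzyl amide

The source may hold more compounds than are shown below. What is called first, only, known or untested is meant among the compounds shown, and "the series" means these compounds.

Compound 1 `C[C@@H](NCc1ccc(OCc2ccccc2)cc1)C(N)=O`: 23.8 mg/kg
Compound 2 `CC[C@@H](NCc1ccc(OCc2ccccc2)cc1)C(N)=O`: 55 mg/kg
Compound 3 `CC[C@H](NCc1ccc(OCc2ccccc2)cc1)C(N)=O`: not yet measured

In a functional assay on the whole organism with Mus musculus as the target (a higher number here means that more compound is needed for the effect, a lower number that less compound is needed), compound 2 has the higher number of the two, at 55 mg/kg. Compound 3 is built from the same pieces: the two compounds have the same atoms and bonds and differ only in configuration as drawn: 1 of 1 stereo elements differ; a stereocentre at a saturated chain carbon is drawn R in compound 2 and S in compound 3. For the measured compounds named here, no measured step shows such a change of configuration. The only one, a 2.3-fold higher number from compound 1 to compound 2 (0.36 log units; beyond the scatter), adds a methyl, so it bears on this change only loosely. Its modest size suggests a modest step here too, with the direction open and only a weak lean towards a lower number. The expected change is a 1.4-fold lower number from compound 2 to compound 3 (0.14 log units; within the scatter). For compound 3 the estimate is 40 mg/kg, with an expected range of 15 mg/kg to 100 mg/kg.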

Compound 3, dose for half-maximal effect: 119 mg/kg
Compound 3: middle estimate off by 3.0-fold (0.47 log units), on the low side; measured number outside the range, above it.
By their numbers in this assay, from the lowest: compound 1; then compound 2; then compound 3.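

In this assay, the configuration at this saturated chain carbon matters in its own right, with a 2.2-fold higher number from compound 2 to compound 3 (0.34 log units; beyond the scatter). This step can come only from the stereocentre, because nothing else changes: the fact that compounds 2 and 3 differ only in the configuration as drawn. With 1-carbamoylpropyl in place of 1-carbamoylethyl on the amine nitrogen, the S form gives a 5.0-fold higher number from compound 1 to compound 3 (0.70 log units; beyond the scatter), the widest step among these compounds.

As far as these compounds go, whether a longer chain at this carbon, or a carboxylic acid in place of the amide, would keep the R form ahead of the S form remains open.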